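The source may hold more compounds than are shown below. What is called first, only, known or untested is meant among the compounds shown, and "the series" means these compounds.

Measured so far in an assay for inhibition of Polyunsaturated fatty acid 5-lipoxygenase (Homo sapiens), read by spectrophotometry, tested at 10 uM, in the presence of a further agent that is not named here; a higher number here means more inhibition at the concentration tested (going by the name of the read-out), a lower number less inhibition:
compound 1, `Cc1nc(NC(=O)c2ccccc2)sc1C(=O)/C=C/c1ccc(Cl)cc1`, giving 63.7%
compound 2, `Cc1nc(NC(=O)c2ccccc2)sc1C(=O)/C=C/c1cccc(Br)c1`, giving 42.5%

Among the measured compounds shown here, compound 1 stands highest of these two numbers; its nearest neighbour is compound 2, and the single measured step, a number 21.2 percentage points lower from compound 1 to compound 2 (beyond the scatter), is a modest loss that lies beyond the scatter. That step changes the halogenated aryl group at the end of the unsaturated chain, not the benzamide part of the shared core.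

Compound 3, `Cc1nc(NC(=O)c2ccc([N+](=O)[O-])cc2)sc1C(=O)/C=C/c1ccc(Cl)cc1`, differs from compound 1 by nitro in place of hydrogen on an aromatic carbon. For the measured compounds named here, no measured step touches that benzamide ring, so the step from compound 1 to compound 2 gives no direct guide to the size or direction of this change. With nothing in the measured pairs pointing either way, compound 3 is expected to stay close to compound 1, with a step of a number 3.7 percentage points lower from compound 1 to compound 3 (within the scatter) that is not expected to exceed the scatter. On that basis compound 3 is estimated at 60%, within a range from 35% to 82%.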

Compound 3, a percentage reported as inhibition, at one concentration (the size of the read-out at that concentration, not a potency): 48.8%
Beside the measured number, compound 3's estimate is 11.2 percentage points above it; low and high end bracket the measured number.
By their numbers in this assay, from the lowest: compounds 2 and 3 (each within the scatter of the next); then compound 1.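

The benzamide end of the shared core is not indifferent in this assay, since phenyl to 4-nitrophenyl, with nitro in place of hydrogen on an aromatic carbon para to a large group, brings a number 14.9 percentage points lower from compound 1 to compound 3 (beyond the scatter), a modest loss. Among the compounds shown here, the earlier step had touched only the halogenated aryl group on the unsaturated chain, so this is the first sign that a change at this second site also moves the number. With compound 1 as the reference, both single changes shown so far lower it. Nothing measured here explains this loss.

Going by these compounds, whether the loss belongs to nitro itself or to any group placed here remains open: an amino group, a methoxy group or a carboxylic acid in place of that hydrogen could go either way. Also open, on these data alone, is whether the same change would cost as much with 3-bromophenyl on the chain as with 4-chlorophenyl.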